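A few compounds are considered here, and "the series" means these few. Any claim that something is new, unique, unknown or untested is made for them only; others in the source may bear on it.

Going by the values given here, in a physicochemical assay for lipophilicity, read by mass spectrometry (on this read-out higher numbers stand for higher lipophilicity and lower numbers for lower lipophilicity), compound 2 `COc1cc2c(cc1OC)C(=O)C(C(=O)Nc1ccc(F)cc1)C2` gives 2.36, the lower of the two numbers so far, while compound 1 `CCc1ccc(NC(=O)C2Cc3cc(OC)c(OC)cc3C2=O)cc1` gives 3.11. Compound 3 `COc1cc2c(cc1OC)C(=O)C(C(=O)Nc1ccc(Cl)cc1)C2`, not yet measured, differs from compound 2 as follows: chloro in place of fluoro on an aromatic carbon. Among the compounds with values here, the one measured step that bears on this is a number 0.75 log units lower from compound 1 to compound 2 (beyond the scatter), for fluoro in place of ethyl on an aromatic carbon, so a rise of somewhat smaller size, beyond the scatter, is expected here. The estimated change is a number 0.49 log units higher from compound 2 to compound 3 (beyond the scatter). The number expected for compound 3 is 2.85, within a range of 2.6 to 3.1.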

Compound 3, partition coefficient: 2.76
The estimate for compound 3 lay 0.09 log units above the measured number; low and high end bracket the measured number.
By their numbers in this assay, from the lowest: compound 2; then compound 3; then compound 1.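

In this assay, chloro in place of fluoro on the aromatic carbon gives a number 0.40 log units higher from compound 2 to compound 3 (beyond the scatter) and so shows that this position responds even when one halogen atom replaces another. Chloro in place of ethyl gives a number 0.35 log units lower from compound 1 to compound 3 (beyond the scatter) and so places chloro between fluoro and ethyl in this set of three. Nothing measured here explains these differences.

Where a nitrile, an amine or a carboxylic acid would fall at this position remains open. So does whether the same order would hold on another core.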